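The source may hold more compounds than are shown below. What is called first, only, known or untested is meant among the compounds shown, and "the series" means these compounds.

Of the compounds shown here, two have been measured in a functional assay on ACHN cells (Homo sapiens) for inhibition, read by sulforhodamine B assay, with a stated time of 48 h; on this read-out lower numbers stand for stronger inhibition of growth and higher numbers for weaker inhibition of growth: compound 1 `N=C(N)c1ccc(-c2ccc(-c3cncc4ccccc34)s2)s1` with 1480 nM, and compound 2 `N=C(N)c1ccc(-c2ccc(-c3ccc(F)cc3)o2)o1` with 1600 nM.

Compound 2 gives a number that differs from that of compound 1 by an amount within the scatter, so the two stand together in this assay and no order between them can be read.

Compound 3 `N=C(N)c1ccc(-c2ccc(-c3ccc(Cl)cc3)o2)o1` has not been measured. It differs from compound 2 by chloro in place of fluoro on an aromatic carbon. Going by the values given here, no measured pair shows a step of this kind, so there is nothing in the data that points to a move in either direction; the expected step from compound 2 to compound 3 is a 1.2-fold lower number from compound 2 to compound 3 (0.09 log units; within the scatter), a change not beyond the scatter. Compound 3 is estimated at 1300 nM, with a range from 500 nM to 3500 nM.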

Compound 3, concentration for 50% growth inhibition: 1890 nM
Compound 3: the middle estimate sits 1.5-fold (0.16 log units) below what was measured; the range from low to high includes it.
By their numbers in this assay, from the lowest: compounds 1, 2 and 3 (each within the scatter of the next).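

In this assay chloro in place of fluoro on an aromatic carbon, para to a large group, gives a 1.2-fold higher number from compound 2 to compound 3 (0.07 log units; within the scatter) and so leaves the two halogens standing together at this position. Going by these compounds alone, this is the first step that can be read between measured compounds differing in one place. Nothing measured here bears on why the two halogens stand together.

The compounds shown leave open whether a methoxy group or an amine at this position would stand with the two halogens. They also leave open how a carboxylic acid there would compare.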